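Removing the Terminal Hydroxy from Compound 2

A few compounds are considered here, and "the series" means these few. Any claim that something is new, unique, unknown or untested is made for them only; others in the source may bear on it.

In a functional assay on HepG2 cells (Homo sapiens) for cytotoxicity, read by MTT assay, with a stated time of 48 h (a higher number here means a weaker inhibitor, a lower number a stronger inhibitor), compound 2 (`O=C(/C=C/c1ccc2c(c1)C(=O)C(=O)N2Cc1ccc(Br)cc1)OCCO`) gives 3660 nM, the highest number of the three measured. Compound 1 (`COc1ccc(CN2C(=O)C(=O)c3cc(/C=C/C(=O)OCCO)ccc32)cc1`) gives 860 nM. Compound 4 (`CCOC(=O)/C=C/c1ccc2c(c1)C(=O)C(=O)N2Cc1ccc(Br)cc1`) keeps the bromo group of compound 2 but has hydrogen in place of hydroxy on a saturated chain carbon, so 2-hydroxyethoxy becomes ethoxy: hydrogen in place of hydroxy on a saturated chain carbon, two bonds along the chain from an oxygen next to a carbonyl group. Among the compounds with values here, the only measured single-place step, a 4.3-fold higher number from compound 1 to compound 2 (0.63 log units; beyond the scatter), is a change on an aromatic carbon and does not size this one. Differing from compound 2 elsewhere too while also lacking the hydroxy, compound 3 (`COC(=O)/C=C/c1ccc2c(c1)C(=O)C(=O)N2Cc1ccc(C)cc1`) gives 40 nM. On that evidence, the expected step is a 9.2-fold lower number from compound 2 to compound 4 (0.96 log units; beyond the scatter), towards a lower number and beyond the scatter. For compound 4 the estimated value is 400 nM, with an expected range of 60 nM to 2500 nM.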

Compound 4, half-maximal inhibitory concentration: 290 nM
Beside the measured number, compound 4's estimate is 1.4-fold (0.14 log units) above it; measured number inside the range.
By their numbers in this assay, from the lowest: compound 3; then compound 4; then compound 1; then compound 2.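

Within the data shown here, with the bromo group unchanged, going from 2-hydroxyethoxy to ethoxy gives a 13-fold lower number from compound 2 to compound 4 (1.10 log units; beyond the scatter) in this assay and so sizes this change on its own for the first time. It shows that the hydroxy on this saturated chain carbon is not needed for a low number here, since its loss moves the number down. Nothing measured here gives a reason for the step.

On these data alone, whether the change has the same size with methoxy on the aromatic carbon remains open. So does the effect of an amine, a carboxylic acid or a longer chain at this chain end.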